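The source may report more compounds than this note shows. Statements on the series, on what has been measured and on what is new or still open speak of the compounds shown alone.

The series shares one core, seen in compound 1 `O=C(/C=C/c1ccc(O)cc1)c1c(O)cccc1OCC1CCCCC1`, compound 2 `CC(C)CCCOc1cccc(O)c1C(=O)/C=C/c1ccc(O)cc1` and compound 3 `O=C(/C=C/c1ccc(O)cc1)c1c(O)cccc1OCCC1CCCCC1`, and differs only in the group on a saturated chain carbon bound to an oxygen on an aromatic ring. In a functional assay on NUGC-3 cells (Homo sapiens) for antiproliferative activity, read by sulforhodamine B assay (on this read-out lower numbers stand for stronger inhibition of growth and higher numbers for weaker inhibition of growth), compound 3 reaches only a limit of the assay, > 30000 nM. Compound 1 likewise gives only a limit, > 30000 nM. Compound 2 gives 3520 nM. The measured steps show an at least 8.5-fold lower number from compound 1 to compound 2 (0.93 log units; beyond the scatter) and an at least 8.5-fold higher number from compound 2 to compound 3 (0.93 log units; beyond the scatter), while a step that the two limits leave unreadable from compound 1 to compound 3; two of the three values sit at the limit of > 30000 nM in this assay, at which 2 of the 3 values shown sit. Compound 4 `CCC(CC)COc1cccc(O)c1C(=O)/C=C/c1ccc(O)cc1` is made from compound 3 by pentan-3-yl in place of cyclohexylmethyl on a saturated chain carbon bound to an oxygen on an aromatic ring. Both readable steps point the same way: the group without a ring in compound 2 gives a lower number than the ring-bearing groups of compound 1 and compound 3. For compound 4 an at least modest fall is therefore expected, as an at least 6.0-fold lower number from compound 3 to compound 4 (0.77 log units; beyond the scatter). Compound 4 is estimated at 5000 nM, within 1500 nM to 20000 nM.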

Compound 4, concentration for 50% growth inhibition: 1960 nM
Compound 4: middle estimate off by 2.6-fold (0.41 log units), on the high side, within the range that was stated.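

In this assay, the change to pentan-3-yl gives an at least 15-fold lower number from compound 3 to compound 4 (1.18 log units; beyond the scatter), and the same group gives an at least 15-fold lower number from compound 1 to compound 4 (1.18 log units; beyond the scatter), so a second group without a ring now stands apart from both ring-bearing groups. Between the two groups without a ring the position shows no readable preference, with a 1.8-fold lower number from compound 2 to compound 4 (0.25 log units; within the scatter), so moving the branch from isopentyl to pentan-3-yl changes nothing that can be told from the scatter. The steps starting from compound 1 and compound 3 start from limits, so their sizes are bounds and not measured differences: the limit of > 30000 nM in this assay, at which 2 of the 4 values shown sit.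

Going by these compounds, what a smaller ring such as cyclopentyl, or a phenyl group, would give at this position stays open. Also open, on these data alone, is whether a longer chain such as octyl would stay level with compound 2 and compound 4.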